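Arylpiperazine swap at the end of the urea chain

The compounds below may be only part of what the source reports. "The series", "measured", "known", "first", "only" and "open" are said of these compounds alone.

Three measured compounds share one core and differ only in the aryl group on the ring nitrogen. Compound 1 `COC(=O)C1=C(C)NC(=O)N(C(=O)NCCCN2CCN(c3ccc(Cl)cc3)CC2)C1c1ccc(F)c(F)c1` gives 0.8 nM in an assay on liver for binding affinity to Alpha-1A adrenergic receptor (Homo sapiens), using microsomes; on this read-out lower numbers stand for stronger inhibition and higher numbers for weaker inhibition. Compound 2 `CCOc1ccccc1N1CCN(CCCNC(=O)N2C(=O)NC(C)=C(C(=O)OC)C2c2ccc(F)c(F)c2)CC1` gives 0.1 nM, and compound 3 `COC(=O)C1=C(C)NC(=O)N(C(=O)NCCCN2CCN(c3cccc(Cl)c3)CC2)C1c1ccc(F)c(F)c1` gives 0.7 nM. Compound 3 stands second highest of the three numbers; its nearest neighbour is compound 1, with a 1.1-fold lower number from compound 1 to compound 3 (0.06 log units; within the scatter), and its furthest is compound 2, with a 7.0-fold higher number from compound 2 to compound 3 (0.85 log units; beyond the scatter).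

Compound 4 `COC(=O)C1=C(C)NC(=O)N(C(=O)NCCCN2CCN(c3ccc(OC)cc3C)CC2)C1c1ccc(F)c(F)c1` carries 4-methoxy-2-methylphenyl in place of 3-chlorophenyl on an amine nitrogen in a ring. Within the data shown here, two steps bear on this change. The move an 8.0-fold lower number from compound 1 to compound 2 (0.90 log units; beyond the scatter) shows that an alkoxy-bearing phenyl gave a clearly lower number than a chlorophenyl, and the reverse 7.0-fold higher number from compound 2 to compound 3 (0.85 log units; beyond the scatter) confirms the same gap. The incoming 4-methoxy-2-methylphenyl again brings an alkoxy group, though at a different position and with a methyl added, so only part of that effect is expected to carry over. Compound 4 is therefore expected to show a 1.8-fold lower number from compound 3 to compound 4 (0.24 log units; within the scatter), a modest move toward a lower number. The estimated value for compound 4 is 0.4 nM, within a range from 0.1 nM to 1.5 nM.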

Compound 4, inhibition constant: 16 nM
Compound 4: the middle estimate sits 40-fold (1.60 log units) below what was measured; the whole stated range lies below it.
By their numbers in this assay, from the lowest: compound 2; then compounds 3 and 1 (each within the scatter of the next); then compound 4.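

An alkoxy group on the phenyl does not by itself go with a lower number: in this assay, 4-methoxy-2-methylphenyl gives a 23-fold higher number from compound 3 to compound 4 (1.36 log units; beyond the scatter) and, against 4-chlorophenyl, a 20-fold higher number from compound 1 to compound 4 (1.30 log units; beyond the scatter). Against 2-ethoxyphenyl, the other alkoxy-bearing aryl group, the change gives a 160-fold higher number from compound 2 to compound 4 (2.20 log units; beyond the scatter), so at this position two alkoxy-bearing phenyl groups lie much further apart than the two chlorophenyl groups do. Nothing available explains this gap.

The methoxy and methyl groups enter together, so the compounds shown cannot tell which of them goes with the higher number, or whether it takes both. They also leave open how an unsubstituted phenyl or a pyridyl group on the same ring nitrogen would read.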